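The compounds below may be only part of what the source reports. "The series", "measured", "known", "first", "only" and "open" are said of these compounds alone.

Measured so far:
- compound 1 `Brc1ccc(/C=N/c2nnc(SCc3c[se]c(-c4ccccc4)n3)s2)cc1`: 14800 nM
- compound 2 `Oc1ccccc1/C=N/c1nnc(SCc2c[se]c(-c3ccccc3)n2)s1`: 15200 nM

In a functional assay on MCF7 cells (Homo sapiens) for antiproliferative activity, read by CCK-8 assay (on this read-out higher numbers stand for weaker inhibition and lower numbers for stronger inhibition), compound 1 gives 14800 nM, and compound 2 gives 15200 nM. Compound 2 stands level with compound 1: the step of a 1.0-fold higher number from compound 1 to compound 2 (0.01 log units; within the scatter) is within the scatter, so the two numbers cannot be told apart. Compound 3 `Cc1ccc(/C=N/c2nnc(SCc3c[se]c(-c4ccccc4)n3)s2)cc1` is the next member of the series, differing from compound 2 in one place: 4-methylphenyl in place of 2-hydroxyphenyl on a carbon with a double bond to nitrogen. Among the measured compounds shown here, the only measured step that speaks to such a swap is the one between compound 1 and compound 2, where a different aromatic group was put on the same carbon, and a 1.0-fold higher number from compound 1 to compound 2 (0.01 log units; within the scatter) shows no movement beyond the scatter. On that basis the step of a 1.0-fold lower number from compound 2 to compound 3 (0.01 log units; within the scatter) is expected to stay within the scatter as well, with no clear direction. Compound 3 is therefore estimated at 15000 nM, with a likely range from 7000 nM to 32000 nM.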

Compound 3, half-maximal inhibitory concentration: 7550 nM
The estimate for compound 3 lay 2.0-fold (0.30 log units) above the measured number; the range from low to high includes it.
By their numbers in this assay, from the lowest: compounds 3, 1 and 2 (each within the scatter of the next).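

In this assay the carbon with a double bond to nitrogen now carries a third aromatic group, and 2-hydroxyphenyl, with its hydrogen-bond donor and acceptor, gives way to 4-methylphenyl, which has neither, with a step that stays within the scatter (a 2.0-fold lower number from compound 2 to compound 3 (0.30 log units; within the scatter)). Methyl in place of bromo on an aromatic carbon also stays within the scatter (a 2.0-fold lower number from compound 1 to compound 3 (0.29 log units; within the scatter)), so compound 1, compound 2 and compound 3 cannot be told apart in this read-out, although both of these steps are larger than the earlier one. There is no outside information that would explain these numbers.

All three groups here are substituted phenyl rings. As far as these compounds go, whether a ring carrying an amine or a carboxylic acid, or one carrying a longer chain such as butyl, would move the number beyond the scatter remains open.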